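The source may report more compounds than this note shows. Statements on the series, on what has been measured and on what is new or still open speak of the compounds shown alone.

Measured so far in a functional assay on HepG2 cells (Homo sapiens) for cytotoxicity, read by MTT assay, with a stated time of 72 h; on this read-out lower numbers stand for higher toxicity in this test and higher numbers for lower toxicity in this test:

Compound 1 `C[Se]/C(=N\C(=O)c1cccs1)NC(=O)c1cccs1` gives 12500 nM.
Compound 2 `CS/C(=N\C(=O)c1ccno1)NC(=O)c1ccno1` gives > 100000 nM.
Compound 3 `O=C(/N=C(/NC(=O)c1cnc2ccccc2c1)[Se]Cc1ccccc1)c1cnc2ccccc2c1` gives 90300 nM.

The value of compound 2 is a limit of the assay, not a number (the limit of > 100000 nM in this assay, at which 1 of the 3 values shown sits). Of the two compounds with a number, compound 1 has the lower one, so it is the more toxic of the two in this test, and compound 3 lies well apart from it.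

Compound 4 `O=C(/N=C(/NC(=O)c1cccs1)[Se]Cc1ccccc1)c1cccs1` has not yet been measured. It differs from compound 1 in one place: phenyl in place of hydrogen on a saturated chain carbon bound to a selenium atom. Within the data shown here, no two measured compounds differ in only one place, so this step has no direct precedent here. The expected step is estimated as a 2.0-fold higher number from compound 1 to compound 4 (0.30 log units; within the scatter) toward a higher number and thus somewhat lower toxicity in this test. Compound 4 is therefore estimated to give about 25000 nM in this assay, within a range of 8000 nM to 80000 nM.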

Compound 4, concentration lethal to 50% of the cells: 81500 nM
Estimate against measurement, compound 4: 3.3-fold (0.51 log units) below, and the stated range ends below it.
By their numbers in this assay, from the lowest: compound 1; then compounds 4 and 3 (each within the scatter of the next). At a limit, above all of these: compound 2.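

Phenyl in place of hydrogen on a saturated chain carbon bound to a selenium atom in this assay gives a 6.5-fold higher number from compound 1 to compound 4 (0.81 log units; beyond the scatter) and so lower toxicity in this test. Among these compounds, this is the first direct reading of any single change in this set, and it shows that this position is not indifferent to what sits there. It rests on one pair and one core, so it sets no general rule.

Open, as far as these compounds go, is where an ethyl chain, or a benzyl carrying an amine, would fall between methyl and benzyl. No measured result here says why the step has this size.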